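The source may hold more compounds than are shown below. What is called first, only, known or untested is meant among the compounds shown, and "the series" means these compounds.

Measured in an ADME assay on microsomes from liver (Mus musculus) for metabolic stability, read by LC-MS, with a stated time of 30 min, tested at 1 uM (a higher number here means that more of the compound is left, a lower number that less of the compound is left), so far:

compound 1, `CCNCc1cc(Cl)cc(Nc2nc3ccccc3n2Cc2ccc(C(F)(F)F)cc2)c1O`, gives 73%
compound 2, `CCNCc1cc(Cl)cc(Nc2nc3cc(F)c(F)cc3[nH]2)c1O`, gives 98%
compound 3, `CCNCc1cc(Cl)cc(Nc2nc3cc(F)c(F)cc3n2Cc2ccc(C(F)(F)F)cc2)c1O`, gives 86%

Compound 1 stands lowest of the three, with compound 3 nearest and compound 2 furthest, both gaps beyond the scatter. Compound 4, `CCNCc1cc(Cl)cc(Nc2nc3ccccc3[nH]2)c1O`, is not yet measured. It differs from compound 1 by hydrogen in place of 4-(trifluoromethyl)benzyl on an aromatic nitrogen. The same change is made from compound 3 to compound 2, (hydrogen in place of 4-(trifluoromethyl)benzyl on an aromatic nitrogen), where the place described is identical word for word, so this is the same change seen once already. It gave a number 12 percentage points higher from compound 3 to compound 2 (beyond the scatter). How the core of compound 1 differs from that of compound 3 is not broken down here.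

Within the data shown here, for compound 4 a step of similar direction and size is expected, a number 12 percentage points higher from compound 1 to compound 4 (beyond the scatter), resting on the one earlier occurrence a number 12 percentage points higher from compound 3 to compound 2 (beyond the scatter) and on the value of compound 1, 73%. Among the measured compounds shown here, with only a single precedent on a different core, the range is kept wide. The estimate for compound 4 is 85%, between 72% and 96%.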

Compound 4, percent of the compound remaining: 97%
Estimate against measurement, compound 4: 12 percentage points below, and the stated range ends below it.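

In this assay, hydrogen in place of 4-(trifluoromethyl)benzyl on the aromatic nitrogen gives a number 24 percentage points higher from compound 1 to compound 4 (beyond the scatter), so the change has now been seen on two cores, with the same direction and with sizes that cannot be told apart: the same change on two cores in this assay, a number 12 percentage points higher (beyond the scatter) from compound 3 to compound 2 and a number 24 percentage points higher (beyond the scatter) from compound 1 to compound 4, 12 percentage points apart, within the scatter of two such steps

Within these two pairs, the change therefore carries over from one core to the other, and the step seen on one core was a fair guide to the direction and rough size on the other. This does not show that it will carry over to further cores, and since the whole 4-(trifluoromethyl)benzyl group leaves at once, neither pair shows which part of that group matters or why the number moves.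

The compounds shown leave open how a methyl, an unsubstituted benzyl or a longer chain ending in an amine or a carboxylic acid would read on that aromatic nitrogen. They also leave open whether any such group would keep as much compound remaining as hydrogen does on either core.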